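Trading Cyano for Trifluoromethoxy: Expecting Compound 4

This account rests on a few compounds, and the source may have more. Where it says the series, first, only, none or still open, it means among the compounds named here.

Four compounds share one core and differ only in the group on the outer aromatic ring. Compound 1 `O=S1(=O)C=Cc2ccc(Nc3cccc(C(F)(F)F)c3)cc21` carries a trifluoromethyl group and gives 1440 nM in a functional assay on A549 cells (Homo sapiens) for antiproliferative activity, read by MTT assay, with a stated time of 72 h; a higher number here means a weaker inhibitor, a lower number a stronger inhibitor. Compound 2 `O=S1(=O)C=Cc2ccc(Nc3ccc(C(F)(F)F)cc3)cc21` places the trifluoromethyl at another position and gives 1140 nM in this assay. Compound 3 `N#Cc1cccc(Nc2ccc3c(c2)S(=O)(=O)C=C3)c1` carries a cyano group instead; in this assay compound 3 reaches only the assay's limit of > 10000 nM, so for compound 3 no exact number is known, only that it is the weakest inhibitor shown. Among the measured compounds shown here, the one step that compares these groups is an at least 6.9-fold higher number from compound 1 to compound 3 (0.84 log units; beyond the scatter), and its size is bounded by the limit of > 10000 nM in this assay, at which 1 of the 3 values shown sits.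

Compound 4 `O=S1(=O)C=Cc2ccc(Nc3cccc(OC(F)(F)F)c3)cc21` is not yet measured. It differs from compound 3 by trifluoromethoxy in place of cyano on an aromatic carbon. Since compound 1 holds the same position with a trifluoromethyl and gives 1440 nM, compound 4 is expected to return toward that level. Compound 4 is therefore estimated at 1600 nM, within 600 nM to 5000 nM. That estimate amounts to an expected improvement of an at least 6.2-fold lower number from compound 3 to compound 4 (0.79 log units; beyond the scatter).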

Compound 4, half-maximal inhibitory concentration: 1370 nM
The estimate for compound 4 lay 1.2-fold (0.07 log units) above the measured number, and the stated range covers the measured number.
By their numbers in this assay, from the lowest: compounds 2, 4 and 1 (each within the scatter of the next). At a limit, above all of these: compound 3.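

In this assay, trifluoromethoxy in place of cyano gives an at least 7.2-fold lower number from compound 3 to compound 4 (0.86 log units; beyond the scatter), and that size is only a bound, since compound 3 stands at a limit of the assay: the limit of > 10000 nM in this assay, at which 1 of the 4 values shown sits.

Trifluoromethoxy and trifluoromethyl cannot be told apart at this position, with a 1.1-fold lower number from compound 1 to compound 4 (0.02 log units; within the scatter). A second group therefore holds the level of compound 1 here, so that level does not rest on trifluoromethyl alone, while compound 3, with its cyano, goes against this pattern.

The compounds shown leave open whether that level would survive an amine, a carboxylic acid or a simple methyl group at this position. Among the compounds shown here, they also leave open whether trifluoromethoxy would match trifluoromethyl at the other position, the one the trifluoromethyl group takes in compound 2.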